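The source may hold more compounds than are shown below. What is called first, only, known or untested is meant among the compounds shown, and "the series" means these compounds.

Compound 1 `O=C1CCC(N2C(=O)c3ccc(Nc4ccccn4)cc3C2=O)C(=O)N1` gives 9% in an assay on FRT-Jurkat cells for inhibition of nuclear factor NF-kappa-B complex (Homo sapiens), read by flow cytometry, with a stated time of 24 h, tested at 10 uM; a lower number here means less inhibition, a higher number more inhibition at the concentration tested (going by the name of the read-out). Compound 2 `CCCCCc1ccc(Nc2ccc3c(c2)C(=O)N(C2CCC(=O)NC2=O)C3=O)cc1` gives 12%. Compound 3 `CN(c1ccccc1)c1ccc2c(c1)C(=O)N(C1CCC(=O)NC1=O)C2=O` gives -2%.

Among the three numbers, compound 3 stands lowest: the nearest is compound 1, and compound 2 lies further above, both differences beyond the scatter. Within the data shown here, the one step that joins two measured compounds in one place is a number 11 percentage points lower from compound 1 to compound 3 (beyond the scatter), a modest fall.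

Compound 4 `O=C1CCC(N2C(=O)c3ccc(Nc4ccc(O)cc4)cc3C2=O)C(=O)N1` differs from compound 3 by (4-hydroxyphenyl)amino in place of methyl(phenyl)amino on an aromatic carbon. Among the measured compounds shown here, the only measured step that bears on this position is the one from compound 1 to compound 3, which reversed the direction now taken: there a group with no hydrogen-bond donor came in and the number fell. Compound 4 brings back an amino group bearing a donor, as compound 1 and compound 2 carry, and both of those sit higher than compound 3. For the measured compounds named here, a rise of roughly the size of that earlier step is therefore expected in this assay, though with only one bearing step the range is wide. Compound 4 is estimated at 10%, between -2% and 22%, so the expected step is a number 12 percentage points higher from compound 3 to compound 4 (beyond the scatter).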

Compound 4, a percentage reported as inhibition, at one concentration (the size of the read-out at that concentration, not a potency): 4%
For compound 4 the middle estimate is 6 percentage points above the measured one, and the stated range covers the measured number.
By their numbers in this assay, from the lowest: compounds 3, 4, 1 and 2 (each within the scatter of the next, the first and the last beyond it).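

In this assay, the change to (4-hydroxyphenyl)amino from methyl(phenyl)amino gives a number 6 percentage points higher from compound 3 to compound 4 (within the scatter), so this exchange, which brings hydrogen-bond donors onto the aromatic carbon, cannot be told apart from the scatter, whereas the earlier step, a number 11 percentage points lower from compound 1 to compound 3 (beyond the scatter), could. Changes at the far end of the amino group are not resolved either: hydroxy in place of pentyl gives a number 8 percentage points lower from compound 2 to compound 4 (within the scatter), and 4-hydroxyphenyl in place of pyridin-2-yl on the nitrogen gives a number 5 percentage points lower from compound 1 to compound 4 (within the scatter). No measurement at hand accounts for any of these steps.

The compounds shown leave open whether a carboxylic acid or a primary amine in place of the hydroxy on this phenyl ring would move the number beyond the scatter from compound 4. They also leave open how these compounds would compare in potency, since each is described here by its inhibition at a single concentration.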